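Hydroxy to fluoro on a fused aromatic core

A few compounds are considered here, and "the series" means these few. Any claim that something is new, unique, unknown or untested is made for them only; others in the source may bear on it.

Compound 1 `O=C(O)c1cnc2cc(OCCOc3ccc(F)cc3)ccc2c1O`: 18200 nM
Compound 2 `O=C(O)c1cnc2cc(O)ccc2c1O`: 490000 nM

In an assay on isolated protein with malate dehydrogenase, mitochondrial (Sus scrofa) as the target (a lower number here means a stronger inhibitor, a higher number a weaker inhibitor), compound 2 gives 490000 nM, the highest of the two numbers measured. Its nearest neighbour is compound 1, which in this assay gives 18200 nM, a lower number by a gap that lies beyond the scatter; the two structures differ in more than one place, so their values are compared only as they stand.

Compound 3 `O=C(O)c1cnc2cc(F)ccc2c1O` is the next compound. Relative to compound 2 the change is fluoro in place of hydroxy on an aromatic carbon. Among the compounds with values here, no step between measured compounds shows this single exchange, so the expectation rests on compound 2 alone. A small step is expected, downward if anything, but it may well stay within the scatter. For compound 3 the estimate in this assay is 300000 nM, within a range of 100000 nM to 1000000 nM, which means an expected step of a 1.6-fold lower number from compound 2 to compound 3 (0.21 log units; within the scatter).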

Compound 3, half-maximal inhibitory concentration: 10500000 nM
Compound 3: middle estimate off by 35-fold (1.54 log units), on the low side; measured number outside the range, above it.
By their numbers in this assay, from the lowest: compound 1; then compound 2; then compound 3.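

In this assay, fluoro in place of hydroxy on this aromatic carbon gives a 21-fold higher number from compound 2 to compound 3 (1.33 log units; beyond the scatter), so a swap of one heavy atom for another at this position is enough to move the number well beyond the scatter. The earlier compounds shown here could not show this, as compound 1 and compound 2 differ in more than one place. Under the computed counts, hydroxy has a hydrogen-bond donor and acceptor and fluoro has neither, but no measurement here links that difference to the step.

The compounds shown leave open whether an amine or a methoxy group on this carbon would stay near compound 2 or move toward compound 3. They also leave open how a plain hydrogen at this place would compare with either.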